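A Methyl-Fluorine Rearrangement on the Amide Aryl Ring

This account rests on a few compounds, and the source may have more. Where it says the series, first, only, none or still open, it means among the compounds named here.

Three amides sharing one core have been examined in a functional assay on MDA-MB-231 cells (Homo sapiens) for antiproliferative activity, read by CCK-8 assay, with a stated time of 72 h; on this read-out higher numbers stand for weaker inhibition and lower numbers for stronger inhibition. Compound 1 `Cc1ccccc1C(=O)Nc1cccc(-c2oc3cc(-c4ccc(F)cc4)ccc3c(=O)c2O)c1` gives 4910 nM, compound 2 `O=C(Nc1cccc(-c2oc3cc(-c4ccc(F)cc4)ccc3c(=O)c2O)c1)c1ccc(C(F)(F)F)cc1` gives 29400 nM, and compound 3 `O=C(Nc1cccc(-c2oc3cc(-c4ccc(F)cc4)ccc3c(=O)c2O)c1)c1cccc(F)c1` gives 2510 nM, the lowest of the three numbers. The steps among them are uneven: a 2.0-fold lower number from compound 1 to compound 3 (0.29 log units; within the scatter), whereas a 12-fold lower number from compound 2 to compound 3 (1.07 log units; beyond the scatter) and a 6.0-fold higher number from compound 1 to compound 2 (0.78 log units; beyond the scatter), so the aryl ring on the carbonyl carbon clearly matters when a trifluoromethyl group sits on it, and less so between the methyl and fluorine variants.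

Compound 4 `Cc1cc(C(=O)Nc2cccc(-c3oc4cc(-c5ccc(F)cc5)ccc4c(=O)c3O)c2)ccc1F` extends this series. The change from compound 3 is 4-fluoro-3-methylphenyl in place of 3-fluorophenyl on a carbonyl carbon. Among the measured compounds shown here, the two steps that bear on it are the one from compound 1 to compound 3, where a methyl was exchanged for a fluorine with no movement beyond the scatter, and the one from compound 2 to compound 3, where removing the bulky para-type substituent gave a large drop. Compound 4 keeps a fluorine and adds a methyl, so the expectation is a small shift, likely within the scatter or a modest rise, a 1.4-fold higher number from compound 3 to compound 4 (0.14 log units; within the scatter). Compound 4 is therefore estimated at 3500 nM, with a range from 1200 nM to 10000 nM.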

Compound 4, half-maximal inhibitory concentration: 7440 nM
Beside the measured number, compound 4's estimate is 2.1-fold (0.33 log units) below it; the measured number falls inside the stated range.
By their numbers in this assay, from the lowest: compounds 3, 1 and 4 (each within the scatter of the next, the first and the last beyond it); then compound 2.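

In this assay, the aryl group on the carbonyl carbon proves sensitive even without a trifluoromethyl group: replacing 3-fluorophenyl with 4-fluoro-3-methylphenyl gives a 3.0-fold higher number from compound 3 to compound 4 (0.47 log units; beyond the scatter). Compound 4 is not separated from the 2-methylphenyl amide, with a 1.5-fold higher number from compound 1 to compound 4 (0.18 log units; within the scatter), yet it remains clear of the 4-(trifluoromethyl)phenyl amide, with a 4.0-fold lower number from compound 2 to compound 4 (0.60 log units; beyond the scatter), so compound 2 is still the weakest of the four, while compound 1 lies within the scatter of both compound 3 and compound 4, although those two are separated beyond it. No measurement offered here accounts for any of these shifts.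

The step to compound 4 adds a methyl and also changes where the fluorine stands on the ring, so these four compounds cannot show which of the two matters; a 4-fluorophenyl or 3-methylphenyl group at this position would be needed to separate them. They also leave open how this position would respond to an aryl ring carrying an amine or a carboxylic acid, or to a longer alkyl chain in place of the ring.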